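Aryl Amine Exchange on a Trifluoromethyl Analogue

A few compounds are considered here, and "the series" means these few. Any claim that something is new, unique, unknown or untested is made for them only; others in the source may bear on it.

Compound 1 `O=C(/C=C\Nc1cnc2ccccc2c1)c1nc(-c2ccccc2)n2ccccc12` is the reference point. In a functional assay on BT-474 cells (Homo sapiens) for cytotoxicity, read by MTT assay, with a stated time of 48 h (on this read-out higher numbers stand for weaker inhibition and lower numbers for stronger inhibition), compound 1 gives 19700 nM. Compound 2 `COc1ccc(N/C=C\C(=O)c2nc(-c3ccccc3)n3ccccc23)cc1` carries 4-methoxyphenyl in place of quinolin-3-yl on an amine nitrogen and in this assay compound 2 gives 12800 nM; the step of a 1.5-fold lower number from compound 1 to compound 2 (0.19 log units; within the scatter) is recorded as within the scatter, so the two values cannot be ordered. Compound 3 `O=C(/C=C\Nc1cnc2ccccc2c1)c1nc(-c2ccc(C(F)(F)F)cc2)n2ccccc12` differs from compound 1 by trifluoromethyl in place of hydrogen on an aromatic carbon. For compound 3, this assay reports only a limit, > 30000 nM. The step of an at least 1.5-fold higher number from compound 1 to compound 3 (0.18 log units; that floor lies within the scatter) is thus a floor rather than a size, as the limit of > 30000 nM in this assay, at which 1 of the 3 values shown sits, shows. Compound 4 `COc1ccc(N/C=C\C(=O)c2nc(-c3ccc(C(F)(F)F)cc3)n3ccccc23)cc1` has not yet been measured. It stands to compound 3 as compound 2 stands to compound 1: the change 4-methoxyphenyl in place of quinolin-3-yl on an amine nitrogen is the same change, made on the same place, while the two cores differ by what trifluoromethyl in place of hydrogen on an aromatic carbon describes. Resting on the earlier step of a 1.5-fold lower number from compound 1 to compound 2 (0.19 log units; within the scatter) and on the limit standing for compound 3, the expected step is an at least 1.0-fold lower number from compound 3 to compound 4 (0.02 log units; that floor lies within the scatter), and compound 4 may well again be reported only as a limit. Compound 4 is estimated at 28000 nM in this assay, between 12000 nM and 60000 nM.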

Compound 4, half-maximal inhibitory concentration: > 30000 nM
Compound 4 gave a limit, no number; the forecaster's own chance of this, stated with the estimate: 55%; middle value at least 1.0-fold (0.02 log units) away from the limit.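

The exchange of quinolin-3-yl for 4-methoxyphenyl cannot be read on the trifluoromethyl-bearing core, since compound 3 and compound 4 are both reported only as limits: the limit of > 30000 nM in this assay, at which 2 of the 4 values shown sit.

Trifluoromethyl in place of hydrogen on an aromatic carbon, with 4-methoxyphenyl on the amine nitrogen, gives an at least 2.3-fold higher number from compound 2 to compound 4 (0.36 log units; beyond the scatter) in this assay, and set beside the same change with quinolin-3-yl, the comparison stands as follows: the same change on two cores in this assay, an at least 1.5-fold higher number (0.18 log units; that floor lies within the scatter) from compound 1 to compound 3 and an at least 2.3-fold higher number (0.36 log units; beyond the scatter) from compound 2 to compound 4; the limit leaves it open whether they differ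

This shows that the trifluoromethyl step lies beyond the scatter with 4-methoxyphenyl in place, but it does not show whether the aryl amine exchange carries over from one core to the other, or whether the trifluoromethyl step has the same size on both.

The compounds shown leave open whether a chlorine or a nitrile in place of trifluoromethyl would give values that can be read as numbers. They also leave open how an aliphatic amine such as morpholine would behave in place of the aryl amines on either core.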